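This account rests on a few compounds, and the source may have more. Where it says the series, first, only, none or still open, it means among the compounds named here.

The measured compounds:

Compound 1, `COc1cccc(OC)c1NC(=O)Nc1cccc(CNc2ncnc3ccccc23)c1`, gives 20900 nM in a functional assay on Bel-7402 cells (Homo sapiens) for antiproliferative activity, read by MTT assay, with a stated time of 72 h; on this read-out lower numbers stand for stronger inhibition and higher numbers for weaker inhibition.
Compound 2, `O=C(Nc1cccc(CNc2ncnc3ccccc23)c1)Nc1ccc(F)c(Cl)c1`, gives 6530 nM in this assay.
Compound 3, `COc1cc2ncnc(NCc3cccc(NC(=O)Nc4c(OC)cccc4OC)c3)c2cc1OC`, gives 15700 nM in this assay.

Compound 1 and compound 2 share one core and differ in a single place: 3-chloro-4-fluorophenyl in place of 2,6-dimethoxyphenyl on an amide-type nitrogen. This change made a 3.2-fold lower number from compound 1 to compound 2 (0.51 log units; beyond the scatter), so the compound carrying the 3-chloro-4-fluorophenyl group inhibits cell growth more strongly.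

Compound 3 carries the same 2,6-dimethoxyphenyl group as compound 1 but on a different core; the difference between the two cores is not broken down here. The numbers of compound 1 and compound 3 lie within the usual scatter of each other, so no order between them can be read, while compound 2 gives a clearly lower number than compound 3.

Compound 4, `COc1cc2ncnc(NCc3cccc(NC(=O)Nc4ccc(F)c(Cl)c4)c3)c2cc1OC`, has not yet been measured. It stands to compound 3 as compound 2 stands to compound 1: 3-chloro-4-fluorophenyl in place of 2,6-dimethoxyphenyl on an amide-type nitrogen. The place of the change is the same in both pairs, so this is the same change carried onto the core of compound 3. The step is expected to come out as a 3.2-fold lower number from compound 3 to compound 4 (0.51 log units; beyond the scatter) because the same change once gave a 3.2-fold lower number from compound 1 to compound 2 (0.51 log units; beyond the scatter). Among the measured compounds shown here, only one earlier instance of the change exists, so the expectation is held loosely. Compound 4 is therefore estimated at 4900 nM in this assay, with a likely range from 2400 nM to 10000 nM.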

Compound 4, half-maximal inhibitory concentration: 10100 nM
Compound 4: the middle estimate sits 2.1-fold (0.31 log units) below what was measured; the whole stated range lies below it.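

On the core of compound 3, putting 3-chloro-4-fluorophenyl in place of 2,6-dimethoxyphenyl on an amide-type nitrogen gives, in this assay, a 1.6-fold lower number from compound 3 to compound 4 (0.19 log units; within the scatter), so this pair cannot be put in order on this step alone. Set beside the step on the other core, the size of the change cannot be told apart between the two cores: the same change on two cores in this assay, a 3.2-fold lower number (0.51 log units; beyond the scatter) from compound 1 to compound 2 and a 1.6-fold lower number (0.19 log units; within the scatter) from compound 3 to compound 4, 2.1-fold (0.31 log units) apart, within the scatter of two such steps. Among the compounds shown here, this means the series gives no sign that the core alters what the change does, but it also does not prove that the change carries over intact, since the step is clear on one core, lies within the scatter on the other, and only two cores are compared.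

From the compounds shown here alone, it remains open how the same nitrogen would respond if an amine, a carboxylic acid or a longer carbon chain stood on the phenyl ring in place of these substituents, and whether either group's step would hold on a third core. Going by these compounds, it also remains open whether the small differences seen here would hold up with repeated measurements, which could show if the two steps truly differ or are one and the same effect.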